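Moving away from the trichlorophenyl group of compound 3

The source may report more compounds than this note shows. Statements on the series, on what has been measured and on what is new or still open speak of the compounds shown alone.

Measured in a functional assay on RT-112 cells (Homo sapiens) for antiproliferative activity, read by MTT assay, with a stated time of 72 h; on this read-out higher numbers stand for weaker inhibition of growth and lower numbers for stronger inhibition of growth:
- compound 1 `COc1cc(Nc2ncnc3c(NC(=O)Nc4ccc(C)c(C)c4)cccc23)cc(OC)c1` gives 8.8 nM
- compound 2 `COc1cc(Nc2ncnc3c(NC(=O)Nc4cccc(Cl)c4Cl)cccc23)cc(OC)c1` gives 63.2 nM
- compound 3 `COc1cc(Nc2ncnc3c(NC(=O)Nc4cc(Cl)c(Cl)cc4Cl)cccc23)cc(OC)c1` gives 4890 nM

Compound 3 has the highest number of the three, so it inhibits growth the least. Compound 4 `COc1cc(Nc2ncnc3c(NC(=O)Nc4ccc(F)cc4C(F)(F)F)cccc23)cc(OC)c1` keeps the shared core but carries 4-fluoro-2-(trifluoromethyl)phenyl in place of 2,4,5-trichlorophenyl on an amide-type nitrogen. The measured compounds differ only in this group, and swapping it has already moved the number a long way. The change to 2,3-dichlorophenyl gave a 7.2-fold higher number from compound 1 to compound 2 (0.86 log units; beyond the scatter) and was modest. The change to 2,4,5-trichlorophenyl gave a 77-fold higher number from compound 2 to compound 3 (1.89 log units; beyond the scatter) and also a 560-fold higher number from compound 1 to compound 3 (2.74 log units; beyond the scatter) and both were large. Compound 3 alone carries 2,4,5-trichlorophenyl and stands apart by a 77-fold higher number from compound 2 to compound 3 (1.89 log units; beyond the scatter) in the data, so removing that group is expected to lower the number. Among the compounds with values here, no measured compound carries the new group, which leaves the size uncertain. An expected step of a 14-fold lower number from compound 3 to compound 4 (1.15 log units; beyond the scatter) in this assay is the working estimate. Compound 4 is estimated at 350 nM (range 40 nM to 3000 nM).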

Compound 4, concentration for 50% growth inhibition: 2970 nM
The estimate for compound 4 lay 8.5-fold (0.93 log units) below the measured number; low and high end bracket the measured number.
By their numbers in this assay, from the lowest: compound 1; then compound 2; then compounds 4 and 3 (each within the scatter of the next).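

In this assay, 4-fluoro-2-(trifluoromethyl)phenyl in place of 2,4,5-trichlorophenyl gives a 1.6-fold lower number from compound 3 to compound 4 (0.22 log units; within the scatter), so the poor result of compound 3 is not peculiar to its chlorine pattern: a phenyl group with different substituents sits level with it. Both remain well apart from the two better compounds, with a 47-fold higher number from compound 2 to compound 4 (1.67 log units; beyond the scatter) and a 340-fold higher number from compound 1 to compound 4 (2.53 log units; beyond the scatter), which shows that this position on the amide-type nitrogen accepts some substituted phenyl groups far better than others. Nothing measured here explains the difference.

These compounds change several substituents at once, so the contribution of each one remains unresolved. From the compounds shown here alone, it also remains open how this position would respond to a phenyl group carrying a single methyl, an amine or a carboxylic acid.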